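The compounds below may be only part of what the source reports. "The series", "measured", "known", "first", "only" and "open" are said of these compounds alone.

Going by the values given here, in a functional assay on A2780 cells (Homo sapiens) for antiproliferative activity (a higher number here means a weaker inhibitor, a lower number a stronger inhibitor), compound 1 `CNC(=O)N1Cc2c(ccc(C)c2C)C(c2ccccc2)C1` stands as "not determined" (no result reported), while compound 2 `Cc1ccc2c(c1C)CN(C(=O)N1CCCCC1)CC2c1ccccc1` gives 2830 nM, the only number so far, so it cannot yet be ranked against anything. Compound 3 `Cc1ccc2c(c1C)CN(C(=O)N(C)CCCN(C)C)CC2c1ccccc1` changes one group: (3-(dimethylamino)propyl)(methyl)amino in place of piperidin-1-yl on a carbonyl carbon, with (3-(dimethylamino)propyl)(methyl)amino in place of piperidin-1-yl on a carbonyl carbon. Among the compounds with values here, no measured step is available to size this change in this assay, so only a modest move towards stronger inhibition is expected, with wide uncertainty. The expected change is a 1.9-fold lower number from compound 2 to compound 3 (0.28 log units; within the scatter). For compound 3 the estimate is 1500 nM, within an expected range of 400 nM to 6000 nM.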

Compound 3, half-maximal inhibitory concentration: 1210 nM
For compound 3 the middle estimate is 1.2-fold (0.09 log units) above the measured one; the range from low to high includes it.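

In this assay, going by these compounds alone, the carbonyl carbon accepts an open chain in place of a ring: (3-(dimethylamino)propyl)(methyl)amino for piperidin-1-yl gives a 2.3-fold lower number from compound 2 to compound 3 (0.37 log units; beyond the scatter) as the first measured step. This modest step shows that the piperidin-1-yl ring is not required at this position for a measurable value. Nothing available bears on the reason for the step. From the compounds shown here alone, whether the terminal dimethylamino group or the loss of the ring matters more remains open. A shorter chain ending in a dimethylamino group, or a piperazine on the same carbonyl carbon, would help separate the two.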